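Compound 4: one added methyl on a weak parent

The compounds below may be only part of what the source reports. "The series", "measured", "known", "first", "only" and "open" are said of these compounds alone.

Values in a functional assay on SEM cells (Homo sapiens) for cytotoxicity, read by MTT assay, with a stated time of 72 h (a lower number here means a stronger inhibitor, a higher number a weaker inhibitor), are as follows
compound 1 `COC(=O)c1sc2nc(C)ccc2c1Nc1cc(OC)c(OC)c(OC)c1` gives 0.5 nM
compound 2 `COC(=O)c1sc2ncccc2c1Nc1cc(OC)c(OC)c(OC)c1` gives 348 nM
compound 3 `CCOC(=O)c1sc2cc(C)ccc2c1Nc1cc(OC)c(OC)c(OC)c1` gives 1.5 nM

Of these three numbers, the highest belongs to compound 2 at 348 nM and it stands well apart from the other two. The change to compound 4 `CCOC(=O)c1sc2ncccc2c1Nc1cc(OC)c(OC)c(OC)c1` is methyl in place of hydrogen on a saturated chain carbon bound to an oxygen next to a carbonyl group and reads methoxycarbonyl to ethoxycarbonyl. Among the compounds with values here, the one measured step is a 700-fold higher number from compound 1 to compound 2 (2.84 log units; beyond the scatter) and it is large, but it is a different change, hydrogen in place of methyl on an aromatic carbon. Compound 3 carries ethoxycarbonyl and gives 1.5 nM on another core, so it sets no size for this change. In this assay no step beyond the scatter is therefore expected, and no direction can be told. The expected step is a 1.1-fold higher number from compound 2 to compound 4 (0.06 log units; within the scatter) and it is small. Compound 4 is estimated at 400 nM with 100 nM and 1500 nM as the expected ends of its range.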

Compound 4, half-maximal inhibitory concentration: 1850 nM
Beside the measured number, compound 4's estimate is 4.6-fold (0.67 log units) below it; measured number above the stated range.
By their numbers in this assay, from the lowest: compound 1; then compound 3; then compound 2; then compound 4.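

In this assay, the change from methoxycarbonyl to ethoxycarbonyl gives a 5.3-fold higher number from compound 2 to compound 4 (0.73 log units; beyond the scatter) and so moves toward a weaker inhibitor. This place, a saturated chain carbon bound to an oxygen next to a carbonyl group, therefore responds to one added methyl on this core, even from an already weak parent. Nothing measured here offers a reason for this step.

As far as these compounds go, whether the same change acts alike on the core of compound 1 stays open. So does the outcome with a longer chain, such as propoxycarbonyl, or with a carboxylic acid in this place.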